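This account rests on a few compounds, and the source may have more. Where it says the series, first, only, none or still open, it means among the compounds named here.

In a functional assay on ECa-109 cells for inhibition, with ECa-109 cell line (Homo sapiens) as the target, read by sulforhodamine B assay (a lower number here means a stronger inhibitor, a higher number a weaker inhibitor), three compounds built on one shared core have been measured. Compound 1 `O=C1C=C(Nc2ccccc2F)C(=O)c2c1nc1n2[C@H]2OC[C@@H](O)[C@H]2OC1` gives 2760 nM and compound 3 `Cc1ccc(NC2=CC(=O)c3nc4n(c3C2=O)[C@H]2OC[C@@H](O)[C@H]2OC4)cc1C` gives 2820 nM, so these two stand level within the scatter. Compound 2 `COc1ccc(NC2=CC(=O)c3nc4n(c3C2=O)[C@H]2OC[C@@H](O)[C@H]2OC4)cc1` gives > 4000 nM, which is a limit of the assay and not a number. Compound 4 `Cc1ccc(NC2=CC(=O)c3nc4n(c3C2=O)[C@H]2OC[C@@H](O)[C@H]2OC4)cc1` has not yet been measured. It differs from compound 3 by hydrogen in place of methyl on an aromatic carbon, turning 3,4-dimethylphenyl into 4-methylphenyl.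

Among the compounds with values here, no measured step removes a single methyl, so the evidence is indirect, coming from exchanges of the whole group on the same amine nitrogen. The exchange in a 1.0-fold higher number from compound 1 to compound 3 (0.01 log units; within the scatter) was negligible. The steps of an at least 1.4-fold higher number from compound 1 to compound 2 (0.16 log units; that floor lies within the scatter) and an at least 1.4-fold lower number from compound 2 to compound 3 (0.15 log units; that floor lies within the scatter) rest on a limit. A step beyond the scatter is therefore not expected, and no direction is favoured strongly. The expected change is a 1.1-fold higher number from compound 3 to compound 4 (0.03 log units; within the scatter). For compound 4 the estimated value is 3000 nM, with an expected range from 1600 nM to 5000 nM.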

Compound 4, half-maximal inhibitory concentration: 3480 nM
Compound 4: middle estimate off by 1.2-fold (0.06 log units), on the low side; measured number inside the range.
By their numbers in this assay, from the lowest: compounds 1, 3 and 4 (each within the scatter of the next). At a limit, above all of these: compound 2.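

In this assay, within the data shown here, the first change confined to a single methyl, 3,4-dimethylphenyl to 4-methylphenyl, gives a 1.2-fold higher number from compound 3 to compound 4 (0.09 log units; within the scatter), so this methyl, on an aromatic carbon ortho to a methyl group, can go without a step beyond the scatter. The 4-methylphenyl group also stands level with the 2-fluorophenyl group on the same amine nitrogen, with a 1.3-fold higher number from compound 1 to compound 4 (0.10 log units; within the scatter). Methyl in place of methoxy gives an at least 1.1-fold lower number from compound 2 to compound 4 (0.06 log units; that floor lies within the scatter), but that step rests on the limit held by compound 2 and cannot be read as a size: the limit of > 4000 nM in this assay, at which 1 of the 4 values shown sits.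

The compounds shown leave open how a plain phenyl group, with no methyl at all, would read at this amine nitrogen. They also leave open how a ring carrying an amine or a carboxylic acid, or a longer chain in place of the ring, would read in this assay.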